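A few compounds are considered here, and "the series" means these few. Any claim that something is new, unique, unknown or untested is made for them only; others in the source may bear on it.

Measured compounds in an assay on HeLa cells for displacement of a labelled ligand from 5-hydroxytryptamine receptor 6 (Homo sapiens); on this read-out lower numbers stand for stronger inhibition and higher numbers for weaker inhibition:
- compound 1 `CN1CCC(n2cc(S(=O)(=O)c3ccccc3)c3cccnc32)C1`: 2.5 nM
- compound 2 `CN1CCC(n2cc(S(=O)(=O)c3ccccc3Cl)c3cccnc32)C1`: 2.2 nM
- compound 3 `O=S(=O)(c1ccccc1)c1cn(C2CCCNC2)c2ncccc12`: 4.9 nM

Compound 3 carries the highest of the three numbers, although the step of a 2.0-fold higher number from compound 1 to compound 3 (0.29 log units; within the scatter) lies within the scatter; only its gap to compound 2 goes beyond it. Compound 4 `O=S(=O)(c1ccccc1Cl)c1cn(C2CCCNC2)c2ncccc12` differs from compound 3 in one place: chloro in place of hydrogen on an aromatic carbon, the place being ortho to a large group, so that phenyl becomes 2-chlorophenyl. The same change has been measured once already, from compound 1 to compound 2, where it gave a 1.1-fold lower number from compound 1 to compound 2 (0.06 log units; within the scatter). That single precedent argues for no step beyond the scatter in this assay, so compound 4 is expected to sit close to compound 3, with the step estimated as a 1.1-fold lower number from compound 3 to compound 4 (0.05 log units; within the scatter). The estimate for compound 4 is therefore 4.4 nM, ranging from 2.2 nM to 9 nM.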

Compound 4, inhibition constant: 3.7 nM
The estimate for compound 4 lay 1.2-fold (0.08 log units) above the measured number; the range from low to high includes it.
By their numbers in this assay, from the lowest: compounds 2, 1, 4 and 3 (each within the scatter of the next, the first and the last beyond it).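

In this assay, chloro in place of hydrogen ortho to a large group now has a second reading on another core, a 1.3-fold lower number from compound 3 to compound 4 (0.12 log units; within the scatter), so the earlier result no longer stands alone: the same change on two cores in this assay, a 1.1-fold lower number (0.06 log units; within the scatter) from compound 1 to compound 2 and a 1.3-fold lower number (0.12 log units; within the scatter) from compound 3 to compound 4, 1.2-fold (0.07 log units) apart, within the scatter of two such steps. The swap of 1-methylpyrrolidin-3-yl for piperidin-3-yl also repeats with 2-chlorophenyl in place of phenyl, a 1.7-fold higher number from compound 2 to compound 4 (0.23 log units; within the scatter): the same change on two cores in this assay, a 2.0-fold higher number (0.29 log units; within the scatter) from compound 1 to compound 3 and a 1.7-fold higher number (0.23 log units; within the scatter) from compound 2 to compound 4, 1.2-fold (0.07 log units) apart, within the scatter of two such steps. Across these four compounds, neither change alters the size of the other beyond the scatter.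

Still open, from the compounds shown here alone, is whether another group at that place, such as an amine or a carboxylic acid, would give a step beyond the scatter.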